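The source may report more compounds than this note shows. Statements on the series, on what has been measured and on what is new or still open speak of the compounds shown alone.

Working notes on the series. In a physicochemical assay for lipophilicity, at pH 7.4 (on this read-out higher numbers stand for higher lipophilicity and lower numbers for lower lipophilicity), compound 1 (`COc1ccc2[nH]c(C)c(Cc3ccccc3)c(=O)c2c1`) gives 2.53, compound 2 (`Cc1[nH]c2ccc(Cl)cc2c(=O)c1Cc1ccccc1`) gives 2.79, and compound 3 (`COc1ccc2c(c1)c(=O)c(Cc1ccccc1)c(C)n2C`) gives 2.73. Compound 3 stands within the scatter of both other compounds, so these three numbers support no firm ranking.

Compound 4 (`Cc1c(Cc2ccccc2)c(=O)c2cc(Cl)ccc2n1C`) has not yet been measured. It differs from compound 3 by chloro in place of methoxy on an aromatic carbon. The same exchange has been measured once, with hydrogen rather than methyl on the aromatic nitrogen: a number 0.26 log units higher from compound 1 to compound 2 (within the scatter). The other measured step is that methyl in place of hydrogen on the aromatic nitrogen: a number 0.20 log units higher from compound 1 to compound 3 (within the scatter). The data do not show whether the two changes add, so the first step serves as the closest guide.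

On the basis of that step to compound 2, a small upward step no larger than the scatter is expected in this assay. The expected step is a number 0.26 log units higher from compound 3 to compound 4 (within the scatter). For compound 4, the estimate is 2.99, with an expected range from 2.7 to 3.3.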

Compound 4, distribution coefficient: 3.21
Compound 4: middle estimate off by 0.22 log units, on the low side; measured number inside the range.
By their numbers in this assay, from the lowest: compounds 1, 3 and 2 (each within the scatter of the next); then compound 4.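

In this assay, chloro in place of methoxy on an aromatic carbon now clears the scatter when the aromatic nitrogen carries methyl: a number 0.48 log units higher from compound 3 to compound 4 (beyond the scatter). With hydrogen on that nitrogen, the same exchange stayed within the scatter: a number 0.26 log units higher from compound 1 to compound 2 (within the scatter). Likewise, methyl in place of hydrogen on the aromatic nitrogen clears the scatter alongside chloro, a number 0.42 log units higher from compound 2 to compound 4 (beyond the scatter), whereas alongside methoxy it did not, a number 0.20 log units higher from compound 1 to compound 3 (within the scatter). Nothing available bears on the cause of these steps.

Among the compounds shown here, each exchange rests on only two pairs, so these compounds do not settle whether the two changes add or reinforce each other. Also open, on these data alone, is how an amine or a carboxylic acid on this aromatic carbon, or a longer chain on the aromatic nitrogen, would read in this assay.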